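The source may report more compounds than this note shows. Statements on the series, on what has been measured and on what is new or still open speak of the compounds shown alone.

Measured so far in an ADME assay on Vero cells (Chlorocebus sabaeus) for cytotoxicity, read by sulforhodamine B assay, with a stated time of 72 h; a lower number here means a stronger inhibitor, a higher number a weaker inhibitor:
Compound 1, `CN1CCc2cc(OCc3ccccc3)ccc2C1`, gives > 100000 nM, which is a limit of the assay rather than a number.
Compound 2, `CN1CCc2cc(OCc3ccc(-c4ccccc4)cc3)ccc2C1`, gives 16500 nM.
Compound 3, `CN1CCc2cc(Oc3ccccc3)ccc2C1`, gives > 100000 nM, again a limit of the assay rather than a number.

Compound 4, `CN1CCc2cc(Oc3ccc(-c4ccccc4)cc3)ccc2C1`, has not yet been measured in this assay.

One structural change is shared by two pairs in this small set. From compound 1 to compound 2 the change is phenyl in place of hydrogen on an aromatic carbon, and from compound 3 to compound 4 it is phenyl in place of hydrogen on an aromatic carbon; the place lines match word for word, so it is the same change on both cores. The difference between the core of compound 1 and the core of compound 3 is not broken down here.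

On the first core the change produced an at least 6.0-fold lower number from compound 1 to compound 2 (0.78 log units; beyond the scatter). The size of that step is known only as a lower bound because of the limit of > 100000 nM in this assay, at which 2 of the 3 values shown sit.

Compound 3 stands at the same limit as compound 1, so the same starting point applies. It is expected that the change will move compound 4 by about an at least 5.0-fold lower number from compound 3 to compound 4 (0.69 log units; beyond the scatter) in this assay, resting on the measured move from compound 1 to compound 2 and on compound 3 sitting at > 100000 nM. From the compounds shown here alone, for compound 4 an estimate of 20000 nM is made, with a range from 7000 nM to 100000 nM; whether the assay gives a number or only a limit remains open.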

Compound 4, half-maximal inhibitory concentration: 22300 nM
The estimate for compound 4 lay 1.1-fold (0.05 log units) below the measured number; the range from low to high includes it.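

In this assay phenyl in place of hydrogen on an aromatic carbon gives an at least 4.4-fold lower number from compound 3 to compound 4 (0.65 log units; beyond the scatter) and so repeats on the core of compound 3 the direction of the move seen on the core of compound 1. This shows that the direction carries across these two cores, but it does not show that the size of the move carries with it, and two cores are too few to support a rule for the series: the same change on two cores in this assay, an at least 6.0-fold lower number (0.78 log units; beyond the scatter) from compound 1 to compound 2 and an at least 4.4-fold lower number (0.65 log units; beyond the scatter) from compound 3 to compound 4; the limit leaves it open whether they differ. Each step is only a lower bound, and neither gives the full size of the move: the limit of > 100000 nM in this assay, at which 2 of the 4 values shown sit.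

The compounds shown leave open whether the move belongs to the phenyl itself or would also follow from a smaller or different group on the same aromatic carbon, such as a methyl, a chlorine or a carboxylic acid. They also leave open where compound 1 and compound 3 would lie on a scale that reaches past the limit, and with that whether the two cores differ at all without the added phenyl.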